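The source may hold more compounds than are shown below. What is called first, only, known or untested is meant among the compounds shown, and "the series" means these compounds.

Measured compounds:
- compound 1, `COc1ccc(OC)c(/C=N/NC(=O)Nc2ccc(Oc3ccnc(-c4nncn4CCN(C)C)c3)c(F)c2)c1`: 2070 nM
- compound 2, `CN(C)CCn1cnnc1-c1cc(Oc2ccc(NC(=O)N/N=C/c3ccc(O)c(Br)c3)cc2F)ccn1`: 450 nM
- compound 3, `COc1ccc(/C=N/NC(=O)Nc2ccc(Oc3ccnc(-c4nncn4CCN(C)C)c3)c(F)c2)cc1O`: 960 nM

These three compounds were tested in a functional assay on HT-29 cells (Homo sapiens) for cytotoxicity, read by MTT assay, with a stated time of 72 h; on this read-out lower numbers stand for stronger inhibition and higher numbers for weaker inhibition. Compound 1 gives the highest number of the three, so it is the weakest of this small set: compound 3 sits nearest to it, and compound 2 furthest away. The two changes seen so far both swap the 2,5-dimethoxyphenyl group for another ring carrying a hydroxyl group, and both lower the number, a 4.6-fold lower number from compound 1 to compound 2 (0.66 log units; beyond the scatter) and a 2.2-fold lower number from compound 1 to compound 3 (0.33 log units; beyond the scatter); between those two, a 2.1-fold higher number from compound 2 to compound 3 (0.33 log units; beyond the scatter).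

Compound 4, `COc1cc(/C=N/NC(=O)Nc2ccc(Oc3ccnc(-c4nncn4CCN(C)C)c3)c(F)c2)cc(OC)c1OC`, has not yet been tested. It differs from compound 1 as follows: 3,4,5-trimethoxyphenyl in place of 2,5-dimethoxyphenyl on a carbon with a double bond to nitrogen. The new ring keeps only methoxy groups and gains a hydrogen-bond acceptor, so the two measured steps bear on it only loosely: they show that this ring position can be changed without harm, and that other rings there gave better numbers, but neither step used a ring without a hydroxyl group. A small step is therefore expected, toward a lower number if anything, and possibly within the scatter. For compound 4 the estimated result in this assay is 1500 nM, with a range from 600 nM to 4000 nM, meaning an expected step of a 1.4-fold lower number from compound 1 to compound 4 (0.14 log units; within the scatter).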

Compound 4, half-maximal inhibitory concentration: 3620 nM
For compound 4 the middle estimate is 2.4-fold (0.38 log units) below the measured one, within the range that was stated.
By their numbers in this assay, from the lowest: compound 2; then compound 3; then compounds 1 and 4 (each within the scatter of the next).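

In this assay the swap of one ring holding only methoxy groups for another, 3,4,5-trimethoxyphenyl in place of 2,5-dimethoxyphenyl, does not move the result beyond the scatter (a 1.7-fold higher number from compound 1 to compound 4 (0.24 log units; within the scatter)), so this pair shows no measurable difference between these two methoxy patterns. The new ring also gives clearly higher numbers than the two rings that carry a hydroxyl group (a 3.8-fold higher number from compound 3 to compound 4 (0.58 log units; beyond the scatter)) and (an 8.0-fold higher number from compound 2 to compound 4 (0.91 log units; beyond the scatter)), which means that among these four compounds both hydroxyl-bearing rings give lower numbers than both rings with methoxy groups alone, and no compound goes against this. No measurement here explains that split.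

The compounds shown leave open whether the hydroxyl group itself accounts for the split, as the rings also differ in their other groups, and compound 2 carries a bromine as well. Also open, on these data alone, is how this position would respond to a quite different group on the ring, such as an amine or a carboxylic acid.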